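The source may hold more compounds than are shown below. What is called first, only, known or untested is meant among the compounds shown, and "the series" means these compounds.

Compound 3 `CCCNCC(=O)N1N=C(c2cc3ccccc3oc2=O)CC1c1ccccc1` gives 4880 nM in a functional assay on MGC-803 cells (Homo sapiens) for cytotoxicity, read by MTT assay, with a stated time of 48 h (on this read-out higher numbers stand for weaker inhibition and lower numbers for stronger inhibition), the lowest of the three numbers in hand. Among the compounds with values here, compound 2 `CC(=O)Oc1ccccc1C1CC(C)=NN1C(=O)CN(C(C)C)C(C)C` gives 20100 nM and compound 1 `CC1=NN(C(=O)c2ccc(C)cc2)C(c2ccccc2O)C1` gives 26300 nM; both gaps to compound 3 lie beyond the scatter, yet no pair of these three differs in a single place, so no step can be read from them. Compound 4 `CN1CCN(CC(=O)N2N=C(c3cc4ccccc4oc3=O)CC2c2ccccc2)CC1` differs from compound 3 in one place: 4-methylpiperazin-1-yl in place of propylamino on a saturated chain carbon bound to a carbonyl carbon. Within the data shown here, no measured step of this kind exists in the set, and nothing in hand points to a direction; a small step is expected, a 1.0-fold higher number from compound 3 to compound 4 (0.01 log units; within the scatter), most likely within the scatter. For compound 4 in this assay the estimate is 5000 nM, with a range from 2000 nM to 12500 nM.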

Compound 4, half-maximal inhibitory concentration: 46100 nM
Compound 4: the middle estimate sits 9.2-fold (0.96 log units) below what was measured, and the stated range ends below it.
By their numbers in this assay, from the lowest: compound 3; then compounds 2, 1 and 4 (each within the scatter of the next, the first and the last beyond it).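

Within the data shown here, the position on a saturated chain carbon bound to a carbonyl carbon is not indifferent to the amine it carries: in this assay the change from propylamino to 4-methylpiperazin-1-yl gives a 9.4-fold higher number from compound 3 to compound 4 (0.98 log units; beyond the scatter) as the first single-place step, towards weaker inhibition. Nothing in hand bears on why this step is so large. One step cannot separate the ring, the hydrogen-bond donor count and the group size, which all change together. As far as these compounds go, how a piperidine, a morpholine or a butylamino group would read at this position stays open.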